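Removing the hydroxy and shifting the pyridine nitrogen

This account rests on a few compounds, and the source may have more. Where it says the series, first, only, none or still open, it means among the compounds named here.

Compound 3 `Cc1ccc(-n2nccn2)c(C(=O)N2C[C@H](C#Cc3cnccc3O)CC[C@H]2C)c1` stands at the higher of the two numbers in a functional assay on isolated protein for antagonist activity at Orexin/Hypocretin receptor type 1 (Homo sapiens), read by FLIPR and calcium flux (a higher number here means a weaker inhibitor, a lower number a stronger inhibitor), where compound 3 gives 3880 nM. Going by the values given here, its nearest neighbour, compound 1 `Cc1ccc(-n2nccn2)c(C(=O)N2C[C@H](C#Cc3cccnc3)CC[C@H]2C)c1`, gives 83 nM in this assay, and the only step reaching compound 3, a 47-fold higher number from compound 1 to compound 3 (1.67 log units; beyond the scatter), was large. Compound 2 `Cc1ccc(-n2nccn2)c(C(=O)N2C[C@H](C#Cc3cncc(CO)c3)CC[C@H]2C)c1` shows "not determined" (no result reported) in this assay. Compound 4 `Cc1ccc(-n2nccn2)c(C(=O)N2C[C@H](C#Cc3ccc(F)cn3)CC[C@H]2C)c1` differs from compound 3 by 5-fluoropyridin-2-yl in place of 4-hydroxypyridin-3-yl on a triple-bonded carbon. Among the compounds with values here, that measured step bears on this change, since the hydroxy leaves again, although the ring nitrogen also moves, which no measured pair covers. The step of a 26-fold lower number from compound 3 to compound 4 (1.41 log units; beyond the scatter) is expected to be a large drop in number because a 47-fold higher number from compound 1 to compound 3 (1.67 log units; beyond the scatter) went the other way. Compound 4 is estimated at 150 nM, within 40 nM to 600 nM.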

Compound 4, half-maximal inhibitory concentration: 31 nM
For compound 4 the middle estimate is 4.8-fold (0.68 log units) above the measured one; the measured number lies below the stated range.
By their numbers in this assay, from the lowest: compound 4; then compound 1; then compound 3.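

In this assay, a 130-fold lower number from compound 3 to compound 4 (2.10 log units; beyond the scatter) shows that the loss seen with 4-hydroxypyridin-3-yl is not general to substituted pyridines on this triple-bonded carbon. The change from pyridin-3-yl is modest but beyond the scatter, a 2.7-fold lower number from compound 1 to compound 4 (0.43 log units; beyond the scatter), so a substituted ring here can even give a lower number than the unsubstituted one. Nothing at hand gives a reason for either step. Fluorine and the ring nitrogen change together in compound 4, so their separate shares remain unresolved. As far as these compounds go, whether a methoxy group or an amine on the ring would behave like fluorine or like hydroxy also stays open.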